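The source may hold more compounds than are shown below. What is called first, only, known or untested is meant among the compounds shown, and "the series" means these compounds.

Compound 1 `Cc1ccccc1NC(=O)N[C@H](C)c1ccccc1` and compound 2 `Cc1ccccc1NC(=O)N[C@@H](C)c1ccccc1` share one core and differ only in configuration as drawn. In an ADME assay on the whole organism with Oryza sativa as the target, tested at 0.1 uM (on this read-out higher numbers stand for a weaker effect at the one concentration tested and lower numbers for a stronger effect), compound 1 gives 100% and compound 2 gives 100%; the step of no change at the digits printed from compound 1 to compound 2 (within the scatter), which rests on (the fact that compounds 1 and 2 differ only in the configuration as drawn). Compound 1 therefore stands level with compound 2 at the digits shown, and the pair offers no measured neighbour that moves the read-out. Compound 3 `CC(C)c1ccccc1NC(=O)N[C@H](C)c1ccccc1` differs from compound 1 by isopropyl in place of methyl on an aromatic carbon. Within the data shown here, no measured step alters a group on the aromatic ring; the only step known, from inverting the stereocentre, stays within the scatter and gives no guidance on the isopropyl. With both measured values at the same level in this assay, no step beyond the scatter is expected for compound 3, in either direction. Compound 3 is thus estimated at 98% in this assay, with a range from 85% to 105%, which means an expected step of a number 2 percentage points lower from compound 1 to compound 3 (within the scatter).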

Compound 3, a percentage reported as activity, at one concentration (the size of the read-out at that concentration, not a potency): 103%
Beside the measured number, compound 3's estimate is 5 percentage points below it; low and high end bracket the measured number.
By their numbers in this assay, from the lowest: compounds 1, 2 and 3 (each within the scatter of the next).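

Isopropyl in place of methyl on an aromatic carbon, ortho to a large group, gives in this assay a number 3 percentage points higher from compound 1 to compound 3 (within the scatter). Among these compounds, this is the first measured change on the aromatic ring, and it shows that this position takes isopropyl with no step beyond the scatter at the one concentration tested, as with the inverted stereocentre in compound 2. Nothing in the data gives a cause for this result.

Going by these compounds, whether an amine, a carboxylic acid or a longer chain on the same aromatic carbon would move the read-out beyond the scatter remains open. Also open is whether isopropyl would give the same result with the stereocentre drawn as in compound 2, and whether any of these compounds would separate at another concentration.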